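A few compounds are considered here, and "the series" means these few. Any claim that something is new, unique, unknown or untested is made for them only; others in the source may bear on it.

Working notes on the series. In a physicochemical assay for solubility, using the shake flask method, in simulated intestinal fluid, measured as kinetic solubility, with a stated time of 2 h, at 25 degrees C, at pH 6.5 (a lower number here means a less soluble compound, a higher number a more soluble compound), compound 1 `Cc1nc(C(=O)O)c(N)c2c1C(=O)N(Cc1ccccc1)C2=O` gives 177000 nM and compound 3 `Cc1noc(-c2nc(C)c3c(c2N)C(=O)N(CC2CCNCC2)C3=O)n1` gives 160000 nM, two values within the scatter of each other. Compound 2 `Cc1nnc(-c2nc(C)c3c(c2N)C(=O)N(Cc2ccccc2)C3=O)o1` gives < 5000 nM, which is a limit of the assay and not a number. Compound 3 therefore sits level with compound 1 at the top of the numbers shown.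

Compound 4 `Cc1noc(-c2nc(C)c3c(c2N)C(=O)N(Cc2cccc(C(F)(F)F)c2)C3=O)n1` replaces piperidin-4-yl in compound 3 with 3-(trifluoromethyl)phenyl, on a saturated chain carbon bound to an amide-type nitrogen in a ring: 3-(trifluoromethyl)phenyl in place of piperidin-4-yl on a saturated chain carbon bound to an amide-type nitrogen in a ring.

Among the compounds with values here, no measured step covers this change. The only one, an at least 35-fold lower number from compound 1 to compound 2 (1.54 log units; beyond the scatter), lies at another place, with 5-methyl-1,3,4-oxadiazol-2-yl in place of carboxy on an aromatic carbon, so it bears only indirectly. Compound 2 is still the closest reference, since it also has an aromatic ring of carbon only on that chain carbon. Its < 5000 nM is a limit.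

A large step to a lower number in this assay is therefore expected, and a result reported only as a limit is likely. The expected change is a 53-fold lower number from compound 3 to compound 4 (1.73 log units; beyond the scatter). For compound 4 the estimated value is 3000 nM, with an expected range of 800 nM to 12000 nM.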

Compound 4, solubility: < 5000 nM
Compound 4 ended at the assay's limit (the forecaster's own chance of this, stated with the estimate: 75%); the middle value is on the limit's open side.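

In this assay the series now has an at least 32-fold lower number from compound 3 to compound 4 (1.50 log units; beyond the scatter), the only step shown at this place, with 3-(trifluoromethyl)phenyl in place of piperidin-4-yl on a saturated chain carbon bound to an amide-type nitrogen in a ring. Compound 3 and compound 4 differ in this one place, so the large step belongs to this exchange, with the rest of the core unchanged, and it shows that this position alone can span a range of the same order as the earlier step at the aromatic carbon. Compound 4 gives < 5000 nM, which is a limit of the assay and not a number, so the step has only a minimum size: the limit of < 5000 nM in this assay, at which 2 of the 4 values shown sit.

The exchange swaps a non-aromatic ring with a nitrogen for an aromatic ring of carbon only and adds trifluoromethyl in one move, and the compounds shown do not separate these parts. As far as these compounds go, how an open-chain amine, a carboxylic acid, a longer chain or a phenyl ring without trifluoromethyl would read at this place on the core of compound 3 remains open.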